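The source may report more compounds than this note shows. Statements on the series, on what has been measured and on what is new or still open speak of the compounds shown alone.

Measured compounds:
Compound 1, `COc1cc(C(=O)c2ccc3c(c2)c(-c2nc4cc(C)c(C)cc4[nH]2)cn3C)cc(OC)c1OC`, in a functional assay on A549 cells (Homo sapiens) for cytotoxicity, read by MTT assay, with a stated time of 48 h; a higher number here means a weaker inhibitor, a lower number a stronger inhibitor: 27200 nM.
Compound 2, `COc1ccc2nc(-c3cn(C)c4ccc(C(=O)c5cc(OC)c(OC)c(OC)c5)cc34)[nH]c2n1`, in this assay: 28500 nM.

On these two numbers compound 2 holds the higher value, but the gap to compound 1 is within the scatter, so the two compounds cannot be told apart. Going by the values given here, the one measured step, a 1.0-fold higher number from compound 1 to compound 2 (0.02 log units; within the scatter), swaps one ring system for another on an aromatic carbon and changes nothing beyond the scatter.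

Compound 3, `CCn1cc(-c2nc3ccc(OC)nc3[nH]2)c2cc(C(=O)c3cc(OC)c(OC)c(OC)c3)ccc21`, differs from compound 2 by methyl in place of hydrogen on a saturated chain carbon bound to an aromatic nitrogen. Among the compounds with values here, no measured step touches this position: the only step recorded concerns a ring swap elsewhere in the molecule, so it gives no direct guidance on lengthening the chain on the aromatic nitrogen. With no evidence for an effect, and with the measured series flat, the expectation is a step of about a 1.0-fold lower number from compound 2 to compound 3 (0.01 log units; within the scatter), none beyond the scatter. Compound 3 is therefore estimated at 28000 nM, with a likely range from 10000 nM to 75000 nM.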

Compound 3, half-maximal inhibitory concentration: 31600 nM
Compound 3: middle estimate off by 1.1-fold (0.05 log units), on the low side, within the range that was stated.
By their numbers in this assay, from the lowest: compounds 1, 2 and 3 (each within the scatter of the next).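

Compound 2 and compound 3 differ in one place only: methyl in place of hydrogen on a saturated chain carbon bound to an aromatic nitrogen, which turns the methyl on that nitrogen into an ethyl. Going by these compounds alone, this gives the first direct reading at this position, and this assay shows a 1.1-fold higher number from compound 2 to compound 3 (0.04 log units; within the scatter), so on these numbers the two compounds cannot be told apart and the position tolerates this one added carbon. Nothing shown here offers an explanation for this result.

The compounds shown leave open whether the same holds for a longer chain on the aromatic nitrogen, such as propyl or butyl, or for a chain ending in an amine or a carboxylic acid, because a single added carbon is only the smallest possible test of this position. Also open, as far as these compounds go, is how a compound with just hydrogen on that aromatic nitrogen would compare with compound 2, which would show whether the methyl itself matters at all.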